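Swapping the Benzyl Arm: From Compound 3 to Compound 4

The compounds below may be only part of what the source reports. "The series", "measured", "known", "first", "only" and "open" are said of these compounds alone.

Compound 1 `O=C(NO)c1ccc(CN(Cc2ccc(C(F)(F)F)cc2)S(=O)(=O)c2c(F)c(F)c(F)c(F)c2F)cc1`: > 1000 nM in an assay on isolated protein for inhibition of histone deacetylase 8 (Homo sapiens), read by mobility shift assay; a lower number here means a stronger inhibitor, a higher number a weaker inhibitor
Compound 2 `O=C(NO)c1ccc(CN(Cc2ccncc2)S(=O)(=O)c2c(F)c(F)c(F)c(F)c2F)cc1`: > 1000 nM
Compound 3 `O=C(NO)c1ccc(CN(Cc2ccncc2)S(=O)(=O)c2cc(F)c(F)c(F)c2F)cc1`: 581 nM

The value of compound 1 is a limit of this assay, not a number. The value of compound 2 is likewise a limit. Among the compounds with values here, compound 3 therefore stands alone as the only number in the set, the other two values being limits (the limit of > 1000 nM in this assay, at which 2 of the 3 values shown sit). The step that the two limits leave unreadable from compound 1 to compound 2 cannot be read, both ends sitting at the limit. Within the data shown here, the step of an at least 1.7-fold lower number from compound 2 to compound 3 (0.23 log units; that floor lies within the scatter) is the one readable change, and its floor lies within the scatter, so even it does not establish a shift.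

Compound 4 `O=C(NO)c1ccc(CN(Cc2ccccc2F)S(=O)(=O)c2cc(F)c(F)c(F)c2F)cc1` differs from compound 3 in one place: 2-fluorophenyl in place of pyridin-4-yl on a saturated chain carbon bound to a sulfonamide nitrogen. Among the measured compounds shown here, the only measured change at this position is the step that the two limits leave unreadable from compound 1 to compound 2, which gives no size, so the data offer no readable guide to how an aryl swap on this carbon moves the number. With nothing to point either way, one expects no step beyond the scatter, while allowing a wide range. Compound 4 is expected at 600 nM, with a range from 250 nM to 1500 nM. That estimate corresponds to a step of a 1.0-fold higher number from compound 3 to compound 4 (0.01 log units; within the scatter), expected to stay within the scatter.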

Compound 4, half-maximal inhibitory concentration: 241 nM
The estimate for compound 4 lay 2.5-fold (0.40 log units) above the measured number; measured number outside the range, below it.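

Placing 2-fluorophenyl where pyridin-4-yl stood, on a saturated chain carbon bound to a sulfonamide nitrogen, gives the first readable size for an aryl swap at this carbon in this assay, and the step is beyond the scatter: a 2.4-fold lower number from compound 3 to compound 4 (0.38 log units; beyond the scatter). The earlier swap at this carbon, between compound 1 and compound 2, cannot be read, as both of those compounds sit at a limit of the assay rather than at a number: the limit of > 1000 nM in this assay, at which 2 of the 4 values shown sit. Nothing measured among the compounds shown accounts for the size or direction of the new step.

The compounds shown leave open whether the step belongs to the fluoro group or to the exchange of the pyridin-4-yl ring for one of carbon only; this single swap changes both at once. They also leave open how this carbon would respond to a plain benzyl group, a cyclohexyl group or a longer chain ending in an amine, and whether the step would hold with a different fluorine pattern on the sulfonyl ring.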